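The compounds below may be only part of what the source reports. "The series", "measured", "known", "first", "only" and "open" are said of these compounds alone.

Measured in a physicochemical assay for solubility, in simulated intestinal fluid; a lower number here means a less soluble compound, a higher number a more soluble compound:
Compound 1 `CN(C)CC[C@H](CSc1ccccc1)Nc1ccc(S(=O)(=O)Nc2nnc3n2CCN(C2CCN(Cc4ccccc4-c4ccc(Cl)cc4)CC2)CC3)cc1S(=O)(=O)C(F)(F)F`: 87000 nM
Compound 2 `CN(C)CC[C@H](CSc1ccccc1)Nc1ccc(S(=O)(=O)Nc2ncnc3c2CCN(C2CCN(Cc4ccccc4-c4ccc(Cl)cc4)CC2)C3)cc1S(=O)(=O)C(F)(F)F`: 64000 nM
Compound 3 `CC(c1ccccc1-c1ccc(Cl)cc1)N1CCC(N2CCc3c(ncnc3NS(=O)(=O)c3ccc(N[C@H](CCN(C)C)CSc4ccccc4)c(S(=O)(=O)C(F)(F)F)c3)C2)CC1`: 31000 nM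

Compound 2 and compound 1 agree within the usual scatter, at the top of this small set. Compound 4 `CN(C)CC[C@H](CSc1ccccc1)Nc1ccc(S(=O)(=O)Nc2nc(Cl)nc3c2CCN(C2CCN(Cc4ccccc4-c4ccc(Cl)cc4)CC2)C3)cc1S(=O)(=O)C(F)(F)F` has chloro in place of hydrogen on an aromatic carbon, between two ring nitrogen atoms: chloro in place of hydrogen on an aromatic carbon. Within the data shown here, only one measured step bears on this, and only loosely, since it changes a different place: methyl in place of hydrogen on a saturated chain carbon gave a 2.1-fold lower number from compound 2 to compound 3 (0.31 log units; beyond the scatter). Among the measured compounds shown here, a similarly modest fall in this assay is therefore expected, though no measurement yet tests chloro here. The estimated step is a 2.0-fold lower number from compound 2 to compound 4 (0.30 log units; within the scatter). For compound 4 the expected value is 32000 nM, with an estimated range from 11000 nM to 75000 nM.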

Compound 4, solubility: 22000 nM
The estimate for compound 4 lay 1.5-fold (0.16 log units) above the measured number, and the stated range covers the measured number.
By their numbers in this assay, from the lowest: compounds 4 and 3 (each within the scatter of the next); then compounds 2 and 1 (each within the scatter of the next).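

In this assay, chloro in place of hydrogen on an aromatic carbon, between two ring nitrogen atoms, gives a 2.9-fold lower number from compound 2 to compound 4 (0.46 log units; beyond the scatter). Among these compounds, this is the first measured change at this position, and it shows that adding one heavy atom here moves the number modestly but beyond the scatter. Nothing available explains this fall.

As far as these compounds go, whether the fall is specific to chloro remains open, and a methoxy group or an amine on this carbon would test that. Also open, from the compounds shown here alone, is whether chloro would produce a similar step in compound 3 , which carries the added methyl.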